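Swapping a Pyridine Ring for Methyl on an Ester Side Chain

A few compounds are considered here, and "the series" means these few. Any claim that something is new, unique, unknown or untested is made for them only; others in the source may bear on it.

Of the compounds shown here, three sharing one core have been measured in an ADME assay on HepG2 2.2.15 cells (Homo sapiens) for cytotoxicity; a higher number here means that more compound is tolerated, a lower number that less compound is tolerated. Compound 1 `CC(=O)OCCc1c(-c2ccccc2Cl)c2cc(Cl)ccc2[nH]c1=O` gives 27000 nM in this assay. Compound 2 `O=C(OCCc1c(-c2ccccc2Cl)c2cc(Cl)ccc2[nH]c1=O)c1cccnc1` gives 170000 nM in this assay. Compound 3 `O=C(/C=C/c1cccnc1)OCCc1c(-c2ccccc2Cl)c2cc(Cl)ccc2[nH]c1=O` gives 39000 nM in this assay. Compound 2 and compound 3 differ by 2-(pyridin-3-yl)ethenyl in place of pyridin-3-yl on a carbonyl carbon; that change gave a 4.4-fold lower number from compound 2 to compound 3 (0.64 log units; beyond the scatter). Compound 1 and compound 3 lie within the usual scatter of each other, as shown by a 1.4-fold higher number from compound 1 to compound 3 (0.16 log units; within the scatter).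

The change from compound 2 to compound 1 is methyl in place of pyridin-3-yl on a carbonyl carbon, and it produced a 6.3-fold lower number from compound 2 to compound 1 (0.80 log units; beyond the scatter). Compound 4 `C/C=C/C(=O)OCCc1c(-c2ccccc2Cl)c2cc(Cl)ccc2[nH]c1=O` has not been measured yet. It arises from compound 3 by methyl in place of pyridin-3-yl on a double-bonded chain carbon bound to a double-bonded chain carbon. This is the same kind of change, not the same change: in compound 2 the pyridin-3-yl sits on a carbonyl carbon whose other neighbours are oxygen next to a carbonyl group, whereas in compound 3 it sits on a double-bonded chain carbon bound to a double-bonded chain carbon.

Because the step of a 6.3-fold lower number from compound 2 to compound 1 (0.80 log units; beyond the scatter) ran toward a lower number, a step of similar direction but less certain size is expected here, namely a 1.8-fold lower number from compound 3 to compound 4 (0.25 log units; within the scatter). Among the compounds with values here, with only one precedent, and that one at a different place, the expectation is loose. Compound 4 is expected to give about 22000 nM in this assay, likely between 9000 nM and 50000 nM.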

Compound 4, half-maximal cytotoxic concentration: 30000 nM
The estimate for compound 4 lay 1.4-fold (0.13 log units) below the measured number; measured number inside the range.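

In this assay, the size of the swap from pyridin-3-yl to methyl did not carry over from one core to the other: the same change on two cores in this assay, a 6.3-fold lower number (0.80 log units; beyond the scatter) from compound 2 to compound 1 and a 1.3-fold lower number (0.11 log units; within the scatter) from compound 3 to compound 4, 4.8-fold (0.69 log units) apart, beyond the scatter of two such steps. The new step, a 1.3-fold lower number from compound 3 to compound 4 (0.11 log units; within the scatter), lies within the scatter, as does a 1.1-fold higher number from compound 1 to compound 4 (0.05 log units; within the scatter), whereas a 5.7-fold lower number from compound 2 to compound 4 (0.75 log units; beyond the scatter) lies beyond it, so among these four compounds only compound 2, with pyridin-3-yl directly on the carbonyl carbon, stands apart. This shows that the same swap can give a clear step at one place and none that can be told from scatter at another, but it rests on a single pair of steps in one assay, and it does not show why the two steps differ or what the swap would do on any further core.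

On these data alone, it remains open whether the high number of compound 2 depends on the ring nitrogen or would also appear with a plain phenyl ring, or with pyridin-4-yl, on the carbonyl carbon. As far as these compounds go, it is equally open how an amine or a carboxylic acid at the end of the ester side chain would read in this assay.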